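Compound 4: hydroxy in place of bromo

This account rests on a few compounds, and the source may have more. Where it says the series, first, only, none or still open, it means among the compounds named here.

Measured in a functional assay on MCF7 cells (Homo sapiens) for antiproliferative activity, read by MTT assay, with a stated time of 72 h; on this read-out higher numbers stand for weaker inhibition and lower numbers for stronger inhibition:
Compound 1 `O=C(N/N=C/c1cccc(Br)c1)Nc1ccc(Oc2ccnc3[nH]ccc23)c(F)c1` gives 49 nM
Compound 2 `O=C(N/N=C/c1ccc(Br)cc1)Nc1ccc(Oc2ccnc3[nH]ccc23)c(F)c1` gives 930 nM
Compound 3 `O=C(N/N=C/c1cccc(Cl)c1Cl)Nc1ccc(Oc2ccnc3[nH]ccc23)c(F)c1` gives "not active" (no number reported)

Of the two compounds with a number, compound 2 stands higher at 930 nM, so it inhibits less strongly. Compound 3 offers no number for comparison. The next compound, compound 4 `O=C(N/N=C/c1ccc(O)cc1)Nc1ccc(Oc2ccnc3[nH]ccc23)c(F)c1`, differs from compound 2 in one place: hydroxy in place of bromo on an aromatic carbon. That is hydroxy in place of bromo on an aromatic carbon. Among the measured compounds shown here, only one measured step bears on this ring, a 19-fold higher number from compound 1 to compound 2 (1.28 log units; beyond the scatter), and it is large. It shows that a change here can matter, but it moves the bromo group and does not replace it, so it gives no direction for hydroxy. In this assay the expected change is therefore modest and uncertain, a 1.3-fold higher number from compound 2 to compound 4 (0.11 log units; within the scatter). For compound 4 the estimated value is 1200 nM, with an expected range from 200 nM to 7000 nM.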

Compound 4, half-maximal inhibitory concentration: "not active" (no number reported)
Nothing numeric was reported for compound 4, so the estimate cannot be set against anything.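

Compound 4 is reported as "not active" in this assay without a number, so no step from compound 2 to compound 4 can be read, and no measurement shown accounts for this result. The compounds shown leave open how far compound 4 lies from compound 2 on a numerical scale.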